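Changing One Amino Group on a Short-Lived Compound

This account rests on a few compounds, and the source may have more. Where it says the series, first, only, none or still open, it means among the compounds named here.

Among the compounds with values here, only two compounds have been read so far in an in vitro ADME assay on microsomes (Rattus norvegicus) for metabolic stability (on this read-out lower numbers stand for a shorter-lived compound and higher numbers for a longer-lived compound), and neither gives a true half-life. Compound 1 `CCc1nc(NC(CC)CC)c(Cl)nc1-c1ccc(Cl)cc1Cl` gives < 0.0167 h, which is a limit of the assay and not a number. Compound 2 `CCc1nc(N(CC2CC2)CC2CC2)c(CC)nc1-c1ccc(Cl)cc1Cl` gives < 0.0167 h, which is also a limit and not a number. Together they show (the limit of < 0.0167 h in this assay, at which 2 of the 2 values shown sit), so compound 2 has no exact position on this scale, and no measured step is available as a guide.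

Compound 3 `CCCN(CCN(C)C)c1nc(CC)c(-c2ccc(Cl)cc2Cl)nc1CC` differs from compound 2 in one place: (2-(dimethylamino)ethyl)(propyl)amino in place of bis(cyclopropylmethyl)amino on an aromatic carbon. On an aromatic carbon, (2-(dimethylamino)ethyl)(propyl)amino replaces bis(cyclopropylmethyl)amino, so the two three-membered rings are lost and a second nitrogen enters the group.

With so little to go on, only a small move towards a longer half-life is expected in this assay, and a reading at the same limit would be no surprise. The expected size of the step of an at least 1.7-fold higher number from compound 2 to compound 3 (0.25 log units; that floor lies within the scatter) is therefore modest. For compound 3 the estimate is 0.03 h, with an expected range of 0.0167 h to 0.08 h.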

Compound 3, half-life: < 0.0167 h
Compound 3: only a limit was reported; the forecaster's own chance of this, stated with the estimate: 50%; at least 1.7-fold (0.25 log units) between middle value and limit.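

In this assay compound 3 gives < 0.0167 h as a limit of the assay and not a number. Within the data shown here, compound 2 also gives only a limit, so no step between compound 2 and compound 3 can be read, and all the compounds shown sit at the same point: (the limit of < 0.0167 h in this assay, at which 3 of the 3 values shown sit). The compounds shown leave open how long any of these half-lives truly is, and whether changing the amino group alters it at all.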